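The compounds below may be only part of what the source reports. "The series", "measured", "known", "first", "only" and "open" are said of these compounds alone.

The study compares two pairs of compounds built on related cores. Compound 1 `O=C1NC(=O)/C(=C/C2=Cc3ccccc3OC2)S1` carries an amide hydrogen on the ring nitrogen, and in a functional assay on A549 cells (Homo sapiens) for antiproliferative activity, read by MTT assay, with a stated time of 72 h (on this read-out lower numbers stand for stronger inhibition and higher numbers for weaker inhibition), compound 1 gives 192000 nM. Compound 2 `CN1C(=O)S/C(=C\C2=Cc3ccccc3OC2)C1=O` differs from it in one place, (methyl in place of hydrogen on an amide-type nitrogen in a ring). In this assay compound 2 returns only a limit, > 100000 nM. The step from compound 1 to compound 2 is therefore a step that the limit leaves unreadable from compound 1 to compound 2, because the result for compound 2 sits at the limit of > 100000 nM in this assay, at which 1 of the 3 values shown sits.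

Compound 3 `CC1Oc2ccc(Br)cc2C=C1/C=C1\SC(=O)NC1=O` has a different core; how the core of compound 3 differs from the core of compound 1 is not broken down here. In this assay compound 3 gives 65500 nM, the lowest of the two readable numbers, and its gap to compound 1 lies beyond the usual scatter.

Compound 4 `CC1Oc2ccc(Br)cc2C=C1/C=C1\SC(=O)N(C)C1=O` has not yet been measured. It differs from compound 3 by methyl in place of hydrogen on an amide-type nitrogen in a ring, the same change as from compound 1 to compound 2, and the place described for it is the same word for word. Since the earlier step was not readable, the expected step from compound 3 to compound 4 can rest only on the value of compound 3, 65500 nM, and on the direction hinted by compound 2. The step that this estimate implies is expected to be a 2.0-fold higher number from compound 3 to compound 4 (0.30 log units; within the scatter). Compound 4 is accordingly estimated at 130000 nM, with a range from 40000 nM to 400000 nM in this assay.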

Compound 4, half-maximal inhibitory concentration: > 50000 nM
Compound 4 gave a limit, no number (the forecaster's own chance of this, stated with the estimate: 50%); the middle value is on the limit's open side.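

In this assay compound 4 gives only a limit, > 50000 nM, and not a number. The step from compound 3 to compound 4 therefore cannot be read, any more than the one from compound 1 to compound 2: the limit of > 50000 nM in this assay, at which 1 of the 4 values shown sits.

The compounds shown leave open how large the step for methyl in place of hydrogen on the amide-type nitrogen is on either core, and whether it runs the same way on both.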